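The compounds below may be only part of what the source reports. "The series", "measured", "known", "first", "only" and "open" are said of these compounds alone.

Measured so far in a functional assay on MDA-MB-231 cells (Homo sapiens) for cytotoxicity, read by MTT assay, with a stated time of 48 h; on this read-out lower numbers stand for stronger inhibition and higher numbers for weaker inhibition:
compound 1, `CCc1ccc(NC(=O)N(Cc2cc(OC)c(OC)c(OC)c2)n2cnnc2)cc1`, gives 24800 nM
compound 2, `COc1cc(CN(C(=O)Nc2ccc(C)cc2)n2cnnc2)cc(OC)c1OC`, gives > 50000 nM

For compound 2 the read-out is only a limit, > 50000 nM, which is the limit of > 50000 nM in this assay, at which 1 of the 2 values shown sits. Among the measured compounds shown here, the single measured step, an at least 2.0-fold higher number from compound 1 to compound 2 (0.30 log units; that floor lies within the scatter), therefore reaches no further than the floor set by that limit, and compound 2 stands at the weak end of what this assay reports.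

Compound 3, `COc1cc(CN(C(=O)Nc2ccc(C#N)cc2)n2cnnc2)cc(OC)c1OC`, differs from compound 2 by cyano in place of methyl on an aromatic carbon. For the measured compounds named here, no measured step exchanges a methyl for a cyano group, so this change has no direct precedent among the two measured compounds; the one measured step concerns a different change and says only how weak the starting point is. Compound 3 is accordingly expected to remain weak in this assay, with an estimated value of 45000 nM (range 15000 nM to 150000 nM). The step this estimate means, an at least 1.1-fold lower number from compound 2 to compound 3 (0.04 log units; that floor lies within the scatter), is expected to stay within the scatter.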

Compound 3, half-maximal inhibitory concentration: > 50000 nM
Compound 3: a limit, no number; the forecaster's own chance of this, stated with the estimate: 55%; at least 1.1-fold (0.04 log units) between middle value and limit.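

In this assay compound 3 gives only a limit, > 50000 nM, so cyano at this place, para to a large group, yields no readable value, just as methyl did. The step between compound 2 and compound 3 cannot be read: both values are limits. Cyano in place of ethyl gives an at least 2.0-fold higher number from compound 1 to compound 3 (0.30 log units; that floor lies within the scatter), and a second compound now rests at the same limit: the limit of > 50000 nM in this assay, at which 2 of the 3 values shown sit.

Ethyl on compound 1 remains the only group at this place with a measured number, and one compound cannot show whether a longer chain such as propyl, an amine or a carboxylic acid would also give a number. From the compounds shown here alone, how much weaker compound 2 and compound 3 really are than their limits show also remains open.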